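A few compounds are considered here, and "the series" means these few. Any claim that something is new, unique, unknown or untested is made for them only; others in the source may bear on it.

Measured compounds:
compound 1 `Cc1cc(C(=O)O)c(C)n1-c1cccc(C#N)c1F` 630 nM
compound 2 `Cc1cc(C(=O)O)c(C)n1-c1ccc(Cl)c(C(F)(F)F)c1` 2100 nM
compound 3 `Cc1cc(C(=O)O)c(C)n1-c1cccc(C(F)(F)F)c1` 1500 nM

In an assay on cells for inhibition of Palmitoleoyl-protein carboxylesterase NOTUM variant C330S (Homo sapiens), read by fluorescence, with a stated time of 40 min (on this read-out lower numbers stand for stronger inhibition and higher numbers for weaker inhibition), compound 3 stands second highest of the three numbers. Its nearest neighbour is compound 2, a step recorded as a 1.4-fold lower number from compound 2 to compound 3 (0.15 log units; within the scatter), hydrogen in place of chloro. Its furthest is compound 1, whose value of 630 nM sits beyond the scatter below compound 3.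

Compound 4 `Cc1cc(C(=O)O)c(C)n1-c1cccc(C#N)c1` differs from compound 3 by cyano in place of trifluoromethyl on an aromatic carbon, cyano in place of trifluoromethyl. Going by the values given here, no measured step covers this exchange directly; compound 1 carries cyano but also a fluorine, so its lower number is only indirect guidance. A modest drop in the number is therefore expected, of the size a 1.7-fold lower number from compound 3 to compound 4 (0.22 log units; within the scatter). Compound 4 is estimated at 900 nM, within 400 nM to 2000 nM.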

Compound 4, half-maximal inhibitory concentration: 3100 nM
Beside the measured number, compound 4's estimate is 3.4-fold (0.54 log units) below it; measured number outside the range, above it.
By their numbers in this assay, from the lowest: compound 1; then compounds 3, 2 and 4 (each within the scatter of the next, the first and the last beyond it).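

On this aromatic carbon, cyano in place of trifluoromethyl gives a 2.1-fold higher number from compound 3 to compound 4 (0.32 log units; beyond the scatter) in this assay, so the nitrile alone does not bring the lower number. Hydrogen in place of fluoro gives a 4.9-fold higher number from compound 1 to compound 4 (0.69 log units; beyond the scatter), which ties the low number of the fluorinated nitrile to the fluoro within this pair. Nothing available accounts for either step. As far as these compounds go, whether fluoro would shift the trifluoromethyl compounds in the same way stays open. So does how a methoxy or an amine on this aromatic carbon would read.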